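The source may report more compounds than this note shows. Statements on the series, on what has been measured and on what is new or still open speak of the compounds shown alone.

Three analogues that share one core have been tested in a functional assay on PC-3 cells (Homo sapiens) for cytotoxicity, read by MTT assay, with a stated time of 48 h; on this read-out higher numbers stand for weaker inhibition and lower numbers for stronger inhibition. Going by the values given here, compound 1 `COc1cc(-c2nnc3n2NC(c2ccco2)C(C(=O)c2cccs2)S3)cc(OC)c1OC` carries a (thiophen-2-yl)carbonyl, and in this assay compound 1 gives 46200 nM, the lowest of the two numbers so far. Compound 2 `COc1cc(-c2nnc3n2NC(c2ccco2)C(C(=O)C2CC2)S3)cc(OC)c1OC` has cyclopropyl in place of thiophen-2-yl on the carbonyl carbon; in this assay compound 2 gives 95200 nM. That step reads a 2.1-fold higher number from compound 1 to compound 2 (0.31 log units; beyond the scatter). Compound 3 `COc1cc(-c2nnc3n2NC(c2ccco2)C(C(=O)c2cccc4ccccc24)S3)cc(OC)c1OC` has naphthalen-1-yl in that place. In this assay compound 3 reaches only a limit, > 100000 nM, as the record notes (the limit of > 100000 nM in this assay, at which 1 of the 3 values shown sits). The corresponding step is an at least 2.1-fold higher number from compound 1 to compound 3 (0.33 log units; beyond the scatter), while the comparison an at least 1.0-fold higher number from compound 2 to compound 3 (0.02 log units; that floor lies within the scatter) settles nothing.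

Compound 4 `COc1cc(-c2nnc3n2NC(c2ccco2)C(C(=O)c2ccc(C(F)(F)F)cc2)S3)cc(OC)c1OC` has not yet been measured. It differs from compound 1 by 4-(trifluoromethyl)phenyl in place of thiophen-2-yl on a carbonyl carbon. Both changes so far made at the carbonyl carbon, a 2.1-fold higher number from compound 1 to compound 2 (0.31 log units; beyond the scatter) and an at least 2.1-fold higher number from compound 1 to compound 3 (0.33 log units; beyond the scatter), moved the number upward, one of them to the limit. A modest rise is therefore expected for this assay, a 1.9-fold higher number from compound 1 to compound 4 (0.29 log units; within the scatter), with a fair chance that only a limit is reported. For compound 4 the expected value in this assay is 90000 nM, within a range from 40000 nM to 200000 nM.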

Compound 4, half-maximal inhibitory concentration: 77500 nM
Compound 4: middle estimate off by 1.2-fold (0.06 log units), on the high side; the measured number falls inside the stated range.
By their numbers in this assay, from the lowest: compounds 1, 4 and 2 (each within the scatter of the next, the first and the last beyond it). At a limit, above all of these: compound 3.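

In this assay, the 4-(trifluoromethyl)phenyl group on the carbonyl carbon gives a measured number that cannot be separated from that of the thiophen-2-yl group: a 1.7-fold higher number from compound 1 to compound 4 (0.22 log units; within the scatter). It also cannot be separated from the cyclopropyl group at this place, a 1.2-fold lower number from compound 2 to compound 4 (0.09 log units; within the scatter), so the earlier gap between thiophen-2-yl and cyclopropyl no longer marks thiophen-2-yl as clearly apart from every other measured group here. The comparison an at least 1.2-fold lower number from compound 3 to compound 4 (0.11 log units; that floor lies within the scatter) cannot be read. Compound 3 stands only at a limit: the limit of > 100000 nM in this assay, at which 1 of the 4 values shown sits.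

As far as these compounds go, all four compounds remain weak in this read-out, with compound 1 at 46200 nM, and it stays open whether any group on this carbonyl carbon, such as an amine, a carboxylic acid or a longer alkyl chain, would give a number clearly lower than that. The rest of the core is the same throughout, so the compounds shown say nothing about changes made elsewhere on it.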